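Dichlorophenyl swap carried onto a second core: working notes

The source may report more compounds than this note shows. Statements on the series, on what has been measured and on what is new or still open speak of the compounds shown alone.

Of the compounds shown here, three have so far been measured in a functional assay on HepG2 cells (Homo sapiens) for cytotoxicity, read by MTT assay, with a stated time of 24 h; a lower number here means a stronger inhibitor, a higher number a weaker inhibitor. Compound 1 `COc1cc(/C=C2\CN(C)C/C(=C\c3ccc(Br)cc3)C2=O)cc(OC)c1` gives 4840 nM. Compound 2 `COc1cc(/C=C2\CN(C)C/C(=C\c3ccc(Cl)cc3Cl)C2=O)cc(OC)c1` carries 2,4-dichlorophenyl in place of 4-bromophenyl on a double-bonded chain carbon bound to a double-bonded ring carbon and gives 6250 nM; the step of a 1.3-fold higher number from compound 1 to compound 2 (0.11 log units; within the scatter). Compound 3 `COc1cc(/C=C2\CN(C)C/C(=C\c3ccc(Br)cc3)C2=O)cc(OC)c1OC` gives 6800 nM; the step of a 1.4-fold higher number from compound 1 to compound 3 (0.15 log units; within the scatter). All three numbers sit within the usual scatter of one another, so no order among compound 1, compound 2 and compound 3 can be read from them.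

Compound 4 `COc1cc(/C=C2\CN(C)C/C(=C\c3ccc(Cl)cc3Cl)C2=O)cc(OC)c1OC` has not yet been measured in this assay. It carries 2,4-dichlorophenyl in place of 4-bromophenyl on a double-bonded chain carbon bound to a double-bonded ring carbon, the same change as from compound 1 to compound 2, made on a core that differs from the core of compound 1 by methoxy in place of hydrogen on an aromatic carbon. The change occurs twice among the compounds shown, and the place it sits is described in the same words both times.

Because the step of a 1.3-fold higher number from compound 1 to compound 2 (0.11 log units; within the scatter) stayed within the scatter, the step from compound 3 to compound 4 is expected to be of similar small size, a 1.3-fold higher number from compound 3 to compound 4 (0.11 log units; within the scatter). Compound 4 is therefore estimated at 8800 nM, with a range from 4500 nM to 17000 nM.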

Compound 4, half-maximal inhibitory concentration: 8800 nM
Compound 4: the middle estimate sits on the measured number at the digits printed; measured number inside the range.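

In this assay, the swap to 2,4-dichlorophenyl on the second core gives a 1.3-fold higher number from compound 3 to compound 4 (0.11 log units; within the scatter), a step that matches the earlier one: the same change on two cores in this assay, a 1.3-fold higher number (0.11 log units; within the scatter) from compound 1 to compound 2 and a 1.3-fold higher number (0.11 log units; within the scatter) from compound 3 to compound 4, 1.0-fold (0.00 log units) apart, within the scatter of two such steps
The methoxy change, read on the 2,4-dichlorophenyl compounds, gives a 1.4-fold higher number from compound 2 to compound 4 (0.15 log units; within the scatter), and this too matches its earlier counterpart: the same change on two cores in this assay, a 1.4-fold higher number (0.15 log units; within the scatter) from compound 1 to compound 3 and a 1.4-fold higher number (0.15 log units; within the scatter) from compound 2 to compound 4, 1.0-fold (0.00 log units) apart, within the scatter of two such steps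
Among these compounds, both changes therefore carry between the two cores with no detectable difference, but every step here lies within the scatter, so this shows only that neither change produces a readable shift on either core, and it does not show that a change with a larger step would carry over in the same way.

Still open, from the compounds shown here alone, is whether a step beyond the scatter exists at all, for example with a phenyl ring carrying an amine or a carboxylic acid in place of 4-bromophenyl. If one does, whether it would keep its size from one core to the other also remains unknown.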